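The source may hold more compounds than are shown below. What is called first, only, known or untested is meant among the compounds shown, and "the series" means these compounds.

Of the compounds shown here, three have so far been measured in a functional assay; a lower number here means a stronger inhibitor, a higher number a weaker inhibitor. Compound 1 `Oc1c(O)c(Br)c(CCc2c(Br)c(O)c(O)c(Br)c2Br)c(Br)c1Br` and compound 3 `Oc1c(O)c(Br)c(COCc2c(Br)c(O)c(O)c(Br)c2Br)c(Br)c1Br` each link two brominated, doubly hydroxylated portions through a short bridge, while compound 2 `CS(=O)(=O)Cc1c(Br)c(O)c(O)c(Br)c1Br` carries only one such portion. In this assay compound 1 gives 10200 nM and compound 3 gives 8500 nM. Compound 2 gives 24000 nM, the highest number of the three and so the weakest inhibitor shown: compound 1 lies nearest to it and compound 3 furthest, and both gaps fall beyond the usual scatter of this kind of measurement.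

Compound 4 `O=Cc1c(Br)c(O)c(O)c(Br)c1Br` keeps the single portion of compound 2 and changes only the group attached to it: formyl in place of (methylsulfonyl)methyl on an aromatic carbon

Among the compounds with values here, no two measured compounds differ in just one place, so there is no measured step to borrow from. Within the data shown here, the shortening from (methylsulfonyl)methyl to formyl is the sole change, and compound 2, the closest relative, already sits at the weak end. The step is therefore expected to be small, with no clear direction and probably not beyond the scatter, giving an estimated 1.2-fold lower number from compound 2 to compound 4 (0.08 log units; within the scatter). Compound 4 is thus expected to give about 20000 nM in this assay, within a range from 6000 nM to 60000 nM.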

Compound 4, half-maximal inhibitory concentration: 24700 nM
For compound 4 the middle estimate is 1.2-fold (0.09 log units) below the measured one, within the range that was stated.
By their numbers in this assay, from the lowest: compounds 3 and 1 (each within the scatter of the next); then compounds 2 and 4 (each within the scatter of the next).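

In this assay, putting formyl in place of (methylsulfonyl)methyl on this aromatic carbon gives a 1.0-fold higher number from compound 2 to compound 4 (0.01 log units; within the scatter), so the two groups cannot be told apart by this read-out. Within the data shown here, this is the first direct comparison at this position, and it shows that the attached group can go from 5 heavy atoms to 2, and from 2 hydrogen-bond acceptors to 1, and lose its sulfur without the number moving beyond the usual scatter. No measurement shown here explains why these two groups read alike.

As far as these compounds go, both groups carry no hydrogen-bond donor and no net charge, so it remains open whether an amine, a carboxylic acid or a longer chain on this same aromatic carbon would move the number in either direction. Compound 1 and compound 3 each differ from compound 2 and compound 4 in more than one place, so the compounds shown cannot say whether the second brominated portion, or any other single feature, accounts for their lower numbers.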